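The compounds below may be only part of what the source reports. "The series", "measured", "known", "first", "only" and "open" are said of these compounds alone.

In an ADME assay on the whole organism (Rattus norvegicus) for pharmacokinetics, at a dose of 1 mg/kg by the intravenous route (on this read-out lower numbers stand for narrower distribution and higher numbers for wider distribution into tissues), three compounds have been measured so far. Compound 1 `COc1ccc(F)cc1-c1c(F)cnc2[nH]c(C3=CCN([C@H]4CC[C@@H](C(=O)O)CC4)CC3)cc12` gives 2.6 L/kg, the second highest of the three numbers. For the measured compounds named here, compound 2 `COc1ccc(F)cc1-c1ccnc2[nH]c(C3=CCN([C@H]4CC[C@@H](C(=O)O)CC4)CC3)cc12` gives 4.7 L/kg, and the one single-point step measured is a 1.8-fold higher number from compound 1 to compound 2 (0.26 log units; within the scatter). Compound 3 `COc1ccc(F)cc1-c1ccnc2[nH]c(C3=CCC(N[C@@H](C(=O)O)C(C)C)CC3)cc12` gives 1 L/kg, and the values of compound 1 and compound 3 lie further apart than the usual scatter. Compound 4 `COc1ccc(F)cc1-c1c(F)cnc2[nH]c(C3=CCN([C@H]4CC[C@H](CC(=O)O)CC4)CC3)cc12` has not yet been measured. It differs from compound 1 in one place: 4-(carboxymethyl)cyclohexyl in place of 4-carboxycyclohexyl on an amine nitrogen in a ring. Going by the values given here, no measured step touches this part of the structure, so none bears on it directly, and the only measured step, on another part, stayed within the scatter. For compound 4 the expected step is therefore no change at the digits printed from compound 1 to compound 4 (within the scatter), not beyond the scatter. Compound 4 is estimated at 2.6 L/kg, with a range from 1.3 L/kg to 5.2 L/kg.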

Compound 4, volume of distribution at steady state: 2.9 L/kg
Compound 4: the middle estimate sits 1.1-fold (0.05 log units) below what was measured; the range from low to high includes it.
By their numbers in this assay, from the lowest: compound 3; then compounds 1, 4 and 2 (each within the scatter of the next).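

For the compounds shown here, the swap to 4-(carboxymethyl)cyclohexyl on the ring amine nitrogen in this assay gives a 1.1-fold higher number from compound 1 to compound 4 (0.05 log units; within the scatter) and is the first measured step at this position. Here, the larger group leaves the read-out within the scatter. No measured evidence explains this result.

Still open, as far as these compounds go, is how this assay would read for a longer chain ending in the carboxylic acid, or for a primary amide in place of that acid. From the compounds shown here alone, the same swap on the core of compound 2 also remains open.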